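Swapping one ring group for diethylcarbamoyl

A few compounds are considered here, and "the series" means these few. Any claim that something is new, unique, unknown or untested is made for them only; others in the source may bear on it.

Compound 1 `CC(C)=CCC[C@]1(C)/C=C/[C@@H](OC(=O)C=C(C)C)[C@](C)(O)/C=C/C(=O)/C(CN=[N+]=[N-])=C\C1` gives 910 nM
Compound 2 `CSC(=S)OC/C1=C/C[C@](C)(CCC=C(C)C)/C=C/[C@@H](OC(=O)C=C(C)C)[C@](C)(O)/C=C/C1=O` gives 180 nM
Compound 3 `CO/N=C/C1=C/C[C@](C)(CCC=C(C)C)/C=C/[C@@H](OC(=O)C=C(C)C)[C@](C)(O)/C=C/C1=O` gives 4760 nM

All three numbers come from a functional assay on HL-60 cells (Homo sapiens) for antiproliferative activity, read by MTT assay, with a stated time of 48 h (a lower number here means a stronger inhibitor, a higher number a weaker inhibitor), and belong to compounds with a shared core. Compound 3 gives 4760 nM and is the weakest inhibitor of the three.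

Compound 4 `CCN(CC)C(=O)/C1=C/C[C@](C)(CCC=C(C)C)/C=C/[C@@H](OC(=O)C=C(C)C)[C@](C)(O)/C=C/C1=O` differs from it in one place, where diethylcarbamoyl enters on a double-bonded ring carbon: a group of 7 heavy atoms (5 carbon, 1 nitrogen, 1 oxygen; no ring) in place of a group of 4 heavy atoms (2 carbon, 1 nitrogen, 1 oxygen; no ring), on a double-bonded ring carbon sums up the swap.

Two measured steps changed the group on this same carbon. The step of a 5.2-fold higher number from compound 1 to compound 3 (0.72 log units; beyond the scatter) is modest, and the step of a 26-fold higher number from compound 2 to compound 3 (1.42 log units; beyond the scatter) is large. Changes here can therefore shift the number considerably, but no measured compound carries diethylcarbamoyl, so the direction is uncertain.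

Since compound 3 stands at 4760 nM at the top of the measured range, a move toward a lower number seems likelier. The expected change is modest, an estimated 2.4-fold lower number from compound 3 to compound 4 (0.38 log units; beyond the scatter) in this assay and probably no larger. For compound 4 the estimate is 2000 nM with an expected range from 500 nM to 8000 nM until it is measured.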

Compound 4, half-maximal inhibitory concentration: 9080 nM
Compound 4: the middle estimate sits 4.5-fold (0.66 log units) below what was measured; the whole stated range lies below it.
By their numbers in this assay, from the lowest: compound 2; then compound 1; then compounds 3 and 4 (each within the scatter of the next).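

Diethylcarbamoyl is larger than the group it replaces, yet the step of a 1.9-fold higher number from compound 3 to compound 4 (0.28 log units; within the scatter) in this assay stays within the scatter, so this assay does not separate these two groups on the double-bonded ring carbon. The other two steps, a 10-fold higher number from compound 1 to compound 4 (1.00 log units; beyond the scatter) and a 50-fold higher number from compound 2 to compound 4 (1.70 log units; beyond the scatter), are both beyond the scatter, and among these four compounds the two with a saturated chain carbon on this ring carbon give the lower numbers, with no compound going against that. Nothing measured here explains this split.

Going by these compounds, it remains open whether the saturated chain carbon itself goes with the lower numbers, or the azide and the sulfur-bearing end beyond it. A hydroxymethyl group, an aminomethyl group or a carboxylic acid on this carbon could help to separate these possibilities.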